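Hexyl chain: ring exchange from compound 3 to compound 4

This account rests on a few compounds, and the source may have more. Where it says the series, first, only, none or still open, it means among the compounds named here.

Values in a functional assay on MCF7 cells (Homo sapiens) for inhibition, read by MTT assay, with stated times of 18 h and 4 h (on this read-out higher numbers stand for weaker inhibition and lower numbers for stronger inhibition), are as follows.
- compound 1 `CCCOP(=O)(O)OCCSC(=S)N1CCCCC1` gives > 100000 nM as a limit
- compound 2 `CCCCCCCCOP(=O)(O)OCCSC(=S)N1CCCCC1` gives 26000 nM as a number
- compound 3 `CCCCCCOP(=O)(O)OCCSC(=S)N1CCCC1` gives 100000 nM as a number
- compound 4 `CCCCCCOP(=O)(O)OCCSC(=S)N1CCCCC1` is not yet measured

Of the two exact values, compound 3 at 100000 nM is the higher and compound 2 at 26000 nM the lower, a gap beyond the scatter. The value of compound 1 is a limit and not a number.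

The next change is piperidin-1-yl in place of pyrrolidin-1-yl on a thiocarbonyl carbon. For the measured compounds named here, no measured step isolates this exchange. Going by the values given here, the only measured step is an at least 3.8-fold lower number from compound 1 to compound 2 (0.58 log units; beyond the scatter) and it changes the chain while piperidin-1-yl stays, so it bears on compound 4 only indirectly. Compound 4 keeps the hexyl chain of compound 3 and takes the piperidin-1-yl of compounds 1 and 2. Its hexyl chain is shorter than the octyl chain of compound 2 at 26000 nM and so compound 4 is expected to stay on the higher side of that value. The expectation in this assay is a small move towards a lower number, with an estimated 1.7-fold lower number from compound 3 to compound 4 (0.22 log units; within the scatter) as the step. The estimate for compound 4 is 60000 nM with 30000 nM to 100000 nM as the expected range.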

Compound 4, half-maximal inhibitory concentration: 62000 nM
Compound 4: middle estimate off by 1.0-fold (0.01 log units), on the low side; measured number inside the range.
By their numbers in this assay, from the lowest: compound 2; then compounds 4 and 3 (each within the scatter of the next).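

In this assay, the exchange of pyrrolidin-1-yl for piperidin-1-yl on a thiocarbonyl carbon can now be read on its own, and with the hexyl chain held fixed it gives a 1.6-fold lower number from compound 3 to compound 4 (0.21 log units; within the scatter) as its step, so at this chain length the two rings are not separated. The chain can also now be read with piperidin-1-yl held fixed and with exact numbers at both ends: a 2.4-fold higher number from compound 2 to compound 4 (0.38 log units; beyond the scatter) is the step, so the octyl chain stands apart from the hexyl chain by a modest gap. The propyl end of the series gives only a floor, an at least 1.6-fold lower number from compound 1 to compound 4 (0.20 log units; that floor lies within the scatter) as printed, and no size can be read from that step because one end of it is a limit of the assay: the limit of > 100000 nM in this assay, at which 1 of the 4 values shown sits.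

Going by these compounds, whether the ring exchange stays this small with the octyl chain remains open, as does the effect of a morpholin-4-yl ring or an open diethylamino group on the thiocarbonyl carbon. Also open, on these data alone, is whether a decyl or dodecyl chain would carry the trend seen from hexyl to octyl any further.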